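Fluoro to trifluoromethyl on the aryl of the shared core

The source may report more compounds than this note shows. Statements on the series, on what has been measured and on what is new or still open speak of the compounds shown alone.

Measured so far:
compound 1 `COc1cc(C2=NN(C(C)=O)C(c3cc(Cl)cc(Cl)c3)O2)cc(OC)c1OC` — 0%
compound 2 `COc1cc(C2=NN(C(C)=O)C(c3cccc(F)c3)O2)cc(OC)c1OC` — 14.7%

In a functional assay on BGC-823 cells (Homo sapiens) for antiproliferative activity, read by MTT assay, tested at 1 uM (a higher number here means a stronger effect of the compound at the concentration tested, a lower number a weaker effect), compound 1 gives 0%, and compound 2 gives 14.7%. Of the two numbers, compound 2 stands highest, with compound 1 as the nearest and lower value, beyond the scatter. Within the data shown here, the only measured step is a number 14.7 percentage points higher from compound 1 to compound 2 (beyond the scatter), a modest gain.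

Compound 3 `COc1cc(C2=NN(C(C)=O)C(c3cccc(C(F)(F)F)c3)O2)cc(OC)c1OC` is not yet measured. Relative to compound 2 the change is trifluoromethyl in place of fluoro on an aromatic carbon. The step bearing on it is a number 14.7 percentage points higher from compound 1 to compound 2 (beyond the scatter), where a 3-fluorophenyl replaced a 3,5-dichlorophenyl and the read-out rose modestly. Among the measured compounds shown here, compound 3 now carries trifluoromethyl in place of fluoro; no measured pair shows the effect of that group directly, so the only guide is that the smaller aryl substituent gave the higher number. A small drop, or no step beyond the scatter, is expected in this assay, as a number 6.7 percentage points lower from compound 2 to compound 3 (within the scatter). For compound 3 the estimate is 8%, within 0% to 25%.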

Compound 3, a percentage reported as inhibition, at one concentration (the size of the read-out at that concentration, not a potency): 27.9%
The estimate for compound 3 lay 19.9 percentage points below the measured number, outside the stated range (above it).
By their numbers in this assay, from the lowest: compound 1; then compound 2; then compound 3.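

In this assay, the aromatic carbon carrying the fluoro group in compound 2 proves open to change: trifluoromethyl in place of fluoro gives a number 13.2 percentage points higher from compound 2 to compound 3 (beyond the scatter), so the group with more heavy atoms carries the higher number in this pair. Set against the dichlorinated aryl, the 3-(trifluoromethyl)phenyl group gives a number 27.9 percentage points higher from compound 1 to compound 3 (beyond the scatter), the widest listed step in this small series, and among these three compounds the aryl group alone orders the read-out, with no compound going against that order. Nothing available on these compounds bears on why the number rises at this position, and the step records only the size of the change in the read-out.

Going by these compounds, whether the rise is specific to trifluoromethyl remains open, and an amine, a carboxylic acid or a methoxy group on the same aromatic carbon of the shared core would test this against the fluoro and trifluoromethyl pair. Also open is how these percentages at one concentration relate to potency, since a read-out of this kind gives the size of the effect only at that concentration and no full concentration response is shown.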